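Halogen pattern change on the sulfonamide aryl group

This account rests on a few compounds, and the source may have more. Where it says the series, first, only, none or still open, it means among the compounds named here.

Compound 1 `COc1ccc(S(=O)(=O)Nc2cc(Br)cc(Br)c2)cc1N1CCNCC1`: 0.501 nM
Compound 2 `COc1cc(Cl)c(C)cc1NS(=O)(=O)c1ccc(OC)c(N2CCNCC2)c1`: 2 nM

In an assay on isolated protein for binding affinity to 5-hydroxytryptamine receptor 6 (Homo sapiens) (a lower number here means a stronger inhibitor, a higher number a weaker inhibitor), compound 1 gives 0.501 nM, the lowest of the two numbers shown; compound 2 gives 2 nM, a gap that lies beyond the usual scatter. Compound 3 `COc1ccc(S(=O)(=O)Nc2cc(Cl)c(Cl)cc2Cl)cc1N1CCNCC1` has not yet been measured. It differs from compound 1 in one place: 2,4,5-trichlorophenyl in place of 3,5-dibromophenyl on a sulfonamide nitrogen. Going by the values given here, because no step between measured compounds covers such a change, the size of the effect cannot be read from the data; the only guide is that both measured compounds, with their different aryl substituents on the sulfonamide nitrogen, stay within a narrow band of this assay. For compound 3 a step of a 2.0-fold higher number from compound 1 to compound 3 (0.30 log units; within the scatter) is expected, a modest weakening that may still fall within the scatter. Compound 3 is therefore estimated at 1 nM, with a likely range from 0.3 nM to 3.5 nM.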

Compound 3, inhibition constant: 5.01 nM
For compound 3 the middle estimate is 5.0-fold (0.70 log units) below the measured one; the whole stated range lies below it.
By their numbers in this assay, from the lowest: compound 1; then compound 2; then compound 3.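

In this assay, the 2,4,5-trichlorophenyl group in place of 3,5-dibromophenyl on a sulfonamide nitrogen gives a 10-fold higher number from compound 1 to compound 3 (1.00 log units; beyond the scatter). This single change, with the rest of compound 1 kept, shows that affinity at this position depends on which halogenated phenyl group is present, a dependence that could not be read from any earlier step. Even so, the position accepts the change without a complete loss of binding, as compound 3 still gives 5.01 nM. Nothing in the available data bears on the origin of this step.

As far as these compounds go, the change alters the kind of halogen, their number and their pattern together, so the share of each remains open. From the compounds shown here alone, how an unsubstituted phenyl group or a trifluoromethyl-bearing phenyl group would fare at this position also remains open.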